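Removing one chloro group from the dichlorophenyl analogue

The source may hold more compounds than are shown below. What is called first, only, known or untested is meant among the compounds shown, and "the series" means these compounds.

Measured so far:
compound 1 `COc1cc(/C=C/C(=O)C2=C(/C=C/c3ccc(O)c(OC)c3)NC(=O)NC2c2ccccc2)ccc1O` gives 15.2% in a functional assay, with a stated time of 20 min, tested at 2 uM; a lower number here means a weaker effect, a higher number a stronger effect of the compound at the concentration tested
compound 2 `COc1cc(/C=C/C(=O)C2=C(/C=C/c3ccc(O)c(OC)c3)NC(=O)NC2c2ccccc2Cl)ccc1O` gives 20.2% in this assay
compound 3 `COc1cc(/C=C/C(=O)C2=C(/C=C/c3ccc(O)c(OC)c3)NC(=S)NC2c2c(Cl)cccc2Cl)ccc1O` gives 17.7% in this assay

All three values lie within the usual scatter of one another, so none of these compounds can be called stronger or weaker than the others. For the measured compounds named here, the one change that occurs twice in this set is hydrogen in place of chloro on an aromatic carbon. Going from compound 2 to compound 1 it made a step of a number 5 percentage points lower from compound 2 to compound 1 (within the scatter).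

Compound 4 `COc1cc(/C=C/C(=O)C2=C(/C=C/c3ccc(O)c(OC)c3)NC(=S)NC2c2ccccc2Cl)ccc1O` is not yet measured. It arises from compound 3 by hydrogen in place of chloro on an aromatic carbon. Going by the values given here, this is the same kind of change as the one between compound 2 and compound 1, but not the same: in compound 3 the place is also meta to a chloro group, which is absent around the place in compound 2. The difference between the core of compound 3 and the core of compound 2 is not broken down here.

Because the earlier step was a number 5 percentage points lower from compound 2 to compound 1 (within the scatter), the step from compound 3 to compound 4 is expected to be small, about a number 2.7 percentage points lower from compound 3 to compound 4 (within the scatter). Compound 4 is therefore estimated at 15% in this assay, most likely between 5% and 28%.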

Compound 4, a percentage reported as activity, at one concentration (the size of the read-out at that concentration, not a potency): 16.2%
The estimate for compound 4 lay 1.2 percentage points below the measured number, and the stated range covers the measured number.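

Replacing chloro with hydrogen on the aromatic ring, which turns 2,6-dichlorophenyl into 2-chlorophenyl, gives a number 1.5 percentage points lower from compound 3 to compound 4 (within the scatter) in this assay. Set beside the earlier step, the same change shows no measurable difference between the two cores: the same change on two cores in this assay, a number 5 percentage points lower (within the scatter) from compound 2 to compound 1 and a number 1.5 percentage points lower (within the scatter) from compound 3 to compound 4, 3.5 percentage points apart, within the scatter of two such steps. This shows that in these two pairs, removing a chloro group leaves the read-out within the scatter on either core, but it does not prove that the change works identically on both, since a true difference smaller than the scatter would stay hidden, and it says nothing about other cores or other concentrations.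

The compounds shown carry only chloro or hydrogen at the positions changed on this ring, so it remains open whether an amine or a carboxylic acid on the ring would shift the read-out beyond the scatter. Also open, going by these compounds, is whether a change away from this ring, such as an ethoxy group in place of the methoxy groups, would do so.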